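Pyridin-4-yl for pyridin-3-yl across two cores

A few compounds are considered here, and "the series" means these few. Any claim that something is new, unique, unknown or untested is made for them only; others in the source may bear on it.

Measured compounds:
compound 1 `CN1C/C(=C\c2cccnc2)C(=O)/C(=C/c2ccc(F)cc2Br)C1` — 13000 nM
compound 2 `CN1C/C(=C\c2ccncc2)C(=O)/C(=C/c2ccc(F)cc2Br)C1` — 9200 nM
compound 3 `O=C1/C(=C/c2cccnc2)CNC/C1=C\c1ccccc1F` — 21000 nM

All values above come from a functional assay on HepG2 cells (Homo sapiens) for cytotoxicity, read by MTT assay, with a stated time of 24 h; on this read-out higher numbers stand for weaker inhibition and lower numbers for stronger inhibition. Compounds 1 and 2 share one core; compound 3 has another, and the difference between the two cores is not broken down here. Within the first core a single change has been measured, (pyridin-4-yl in place of pyridin-3-yl on a double-bonded chain carbon bound to a double-bonded ring carbon), and it gave a 1.4-fold lower number from compound 1 to compound 2 (0.15 log units; within the scatter). Compound 3 gives the highest number of the three, though its gap to compound 1 is within the scatter and only its gap to compound 2 lies beyond it.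

Compound 4 `O=C1/C(=C/c2ccncc2)CNC/C1=C\c1ccccc1F` stands to compound 3 as compound 2 stands to compound 1: pyridin-4-yl in place of pyridin-3-yl on a double-bonded chain carbon bound to a double-bonded ring carbon. The place is described in the same words for both pairs, so it is the same change, now made on the second core. Among the compounds with values here, with one earlier instance as the only guide, a step of about a 1.4-fold lower number from compound 3 to compound 4 (0.15 log units; within the scatter) is expected from compound 3 to compound 4 in this assay, resting on a 1.4-fold lower number from compound 1 to compound 2 (0.15 log units; within the scatter). The estimate for compound 4 is 15000 nM, expected to fall between 7000 nM and 32000 nM.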

Compound 4, half-maximal inhibitory concentration: 8200 nM
Compound 4: middle estimate off by 1.8-fold (0.26 log units), on the high side, and the stated range covers the measured number.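

In this assay, pyridin-4-yl in place of pyridin-3-yl gives a 2.6-fold lower number from compound 3 to compound 4 (0.41 log units; beyond the scatter), so on this core the change moves the number beyond the scatter. The two steps run in the same direction, but their sizes cannot be told apart: the same change on two cores in this assay, a 1.4-fold lower number (0.15 log units; within the scatter) from compound 1 to compound 2 and a 2.6-fold lower number (0.41 log units; beyond the scatter) from compound 3 to compound 4, 1.8-fold (0.26 log units) apart, within the scatter of two such steps This supports carrying the change between these two cores only as a step towards a lower number of uncertain size; with just two pairs, and with the earlier step alone within the scatter, it does not show that the step is fixed in size, that it would hold on a further core, or which differences between the cores matter.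

Still open, on these data alone, is whether pyridin-2-yl, or a phenyl carrying an amine or a carboxylic acid, on a double-bonded chain carbon bound to a double-bonded ring carbon would give a lower number than pyridin-4-yl. Also open, as far as these compounds go, is whether the gap between compound 3 and compound 4 persists in any other cell line.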